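A few compounds are considered here, and "the series" means these few. Any claim that something is new, unique, unknown or untested is made for them only; others in the source may bear on it.

Measured so far:
Compound 1, `N#Cc1cnc(NCc2cnccc2C(F)(F)F)cc1NC[C@H]1CC[C@@H](O)CC1`: 500 nM
Compound 2, `CNC(=O)[C@H]1CC[C@@H](Nc2cc(NCc3cnccc3C(F)(F)F)ncc2C#N)CC1`: 1600 nM

Both numbers come from an assay on isolated protein for inhibition of protein kinase C delta type (Homo sapiens), read by TR-FRET, with a stated time of 2 h; a lower number here means a stronger inhibitor, a higher number a weaker inhibitor. Among the compounds with values here, of the two compounds measured, compound 2 shows the higher number, and its only neighbour is compound 1; the step of a 3.2-fold higher number from compound 1 to compound 2 (0.51 log units; beyond the scatter) lies beyond the usual scatter. Compound 3, `CC1(C)C[C@H](Nc2cc(NCc3cnccc3C(F)(F)F)ncc2C#N)CC[C@@H]1O`, has not yet been measured. It differs from compound 2 in one place: 4-hydroxy-3,3-dimethylcyclohexyl in place of 4-(methylcarbamoyl)cyclohexyl on a nitrogen on an aromatic ring. Within the data shown here, the one measured step that bears on this change is a 3.2-fold higher number from compound 1 to compound 2 (0.51 log units; beyond the scatter), in which a hydroxyl-bearing substituent on that same nitrogen gave way to the 4-(methylcarbamoyl)cyclohexyl group and the number rose by a modest margin. Compound 3 brings a hydroxyl back onto the ring, though now on a cyclohexyl bound directly to the nitrogen and carrying two methyl groups, so the earlier step is only a partial guide. Because a 3.2-fold higher number from compound 1 to compound 2 (0.51 log units; beyond the scatter) was modest, a modest step downward is expected for compound 3 in this assay, estimated as a 2.0-fold lower number from compound 2 to compound 3 (0.30 log units; within the scatter). Compound 3 is therefore expected to give 800 nM, within a range of 300 nM to 2500 nM.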

Compound 3, half-maximal inhibitory concentration: 500 nM
For compound 3 the middle estimate is 1.6-fold (0.20 log units) above the measured one; the range from low to high includes it.
By their numbers in this assay, from the lowest: compounds 1 and 3 (each within the scatter of the next); then compound 2.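

In this assay, putting 4-hydroxy-3,3-dimethylcyclohexyl in place of 4-(methylcarbamoyl)cyclohexyl on the nitrogen gives a 3.2-fold lower number from compound 2 to compound 3 (0.51 log units; beyond the scatter), so the rise seen with the 4-(methylcarbamoyl)cyclohexyl group is not fixed to the shared core and can be undone at this one position. Against the (4-hydroxycyclohexyl)methyl group, the same new substituent gives no change at the digits printed from compound 1 to compound 3 (within the scatter), which shows that two differently built hydroxyl-bearing groups can stand level at this nitrogen, while compound 2, the one with the methylcarbamoyl group, stands apart from both. Nothing in the data given accounts for these differences.

The compounds shown leave open what the two methyl groups contribute, and whether a plain 4-hydroxycyclohexyl bound directly to the nitrogen would stand with compound 1 and compound 3 or with compound 2. Also open, on these data alone, is how an amine or a carboxylic acid in place of the hydroxyl on this ring would read in this assay, and whether the stereocentres of the 4-hydroxy-3,3-dimethylcyclohexyl group matter there.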